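The source may hold more compounds than are shown below. What is called first, only, known or untested is meant among the compounds shown, and "the series" means these compounds.

Three compounds have been measured in an assay on isolated protein for inhibition of serine/threonine-protein kinase TNNI3K (Homo sapiens); a lower number here means a stronger inhibitor, a higher number a weaker inhibitor:

Compound 1 `O=C(Nc1ccc(Oc2cc(O)ncn2)cc1)Nc1cccc(C(F)(F)F)c1` gives 3200 nM.
Compound 2 `CC(C)Nc1cc(Oc2ccc(NC(=O)Nc3cccc(C(F)(F)F)c3)cc2)ncn1` gives 40 nM.
Compound 3 `C[C@H](O)CNc1cc(Oc2ccc(NC(=O)Nc3cccc(C(F)(F)F)c3)cc2)ncn1` gives 32 nM.

Compound 3 has the lowest of the three numbers in this assay. Its nearest neighbour is compound 2, with a 1.3-fold lower number from compound 2 to compound 3 (0.10 log units; within the scatter), a step within the usual scatter. Its furthest is compound 1, with a 100-fold lower number from compound 1 to compound 3 (2.00 log units; beyond the scatter); the related step of an 80-fold lower number from compound 1 to compound 2 (1.90 log units; beyond the scatter) is of the same kind, both large and both arising where the hydroxy on the aromatic carbon is replaced by an amino group.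

Compound 4 `CC(C)(O)CNc1cc(Oc2ccc(NC(=O)Nc3cccc(C(F)(F)F)c3)cc2)ncn1` differs from compound 3 in this way: 1-hydroxy-1-methylethyl in place of 1-hydroxyethyl on a saturated chain carbon bound to a nitrogen on an aromatic ring. The large steps from compound 1 concern a different place and do not bear on this change. Among the compounds with values here, the only step that touches the chain on the ring nitrogen is the one from compound 2 to compound 3, and it stayed within the scatter. Compound 4 is therefore expected to show a 1.1-fold higher number from compound 3 to compound 4 (0.04 log units; within the scatter), that is, no change beyond the scatter. The estimated value of compound 4 in this assay is 35 nM, with a range from 15 nM to 80 nM.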

Compound 4, half-maximal inhibitory concentration: 40 nM
For compound 4 the middle estimate is 1.1-fold (0.06 log units) below the measured one, within the range that was stated.
By their numbers in this assay, from the lowest: compounds 3, 2 and 4 (each within the scatter of the next); then compound 1.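

In this assay, the 1-hydroxy-1-methylethyl group adds a carbon and carries no defined stereocentre, yet the number stays within the scatter (a 1.3-fold higher number from compound 3 to compound 4 (0.10 log units; within the scatter)). Set against the isopropyl of compound 2, the 2-hydroxy-2-methylpropyl group also gives no separation (no change at the digits printed from compound 2 to compound 4 (within the scatter)), so these three chains on the nitrogen cannot be told apart in this assay, while the large step from the hydroxy compound holds for this amino group too (an 80-fold lower number from compound 1 to compound 4 (1.90 log units; beyond the scatter)). Nothing available offers an explanation for this flat result.

From the compounds shown here alone, it remains open whether the chain would stay as undemanding with a longer chain, such as 3-hydroxypropyl, or with a terminal amine or carboxylic acid in place of the hydroxy. A ring on the nitrogen, such as cyclopropyl, is likewise untested by the compounds shown.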